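Shrinking the Amide Substituent from Benzyl to Ethyl

This account rests on a few compounds, and the source may have more. Where it says the series, first, only, none or still open, it means among the compounds named here.

Of the compounds shown here, two have so far been measured in a functional assay on IMR-32 cells (Homo sapiens) for antiproliferative activity, read by sulforhodamine B assay, with a stated time of 48 h; on this read-out higher numbers stand for weaker inhibition and lower numbers for stronger inhibition. Compound 1 `COc1ccc(C[C@@H](O)/C=C/C=C/C(=O)NCc2ccccc2)cc1OC` gives 16600 nM and stands at the highest number of the two. Compound 2 `COc1ccc(C[C@@H](O)/C=C/C=C/C(=O)N2CCN(c3ccccc3)CC2)cc1OC` gives 9430 nM in this assay; the gap between these two numbers lies within the scatter of repeated measurements, so the two compounds cannot be told apart on this read-out. Compound 3 `CCNC(=O)/C=C/C=C/[C@H](O)Cc1ccc(OC)c(OC)c1` has not yet been measured. It differs from compound 1 by methyl in place of phenyl on a saturated chain carbon bound to an amide-type nitrogen, which, cut one bond further out, reads as benzyl to ethyl. For the measured compounds named here, no measured pair shows a change of this kind, so there is no step to lean on. Since compound 1 already gives 16600 nM, compound 3 is expected to give a similar or somewhat higher number, a step of a 1.5-fold higher number from compound 1 to compound 3 (0.18 log units; within the scatter) that may well stay within the scatter. The estimate for compound 3 is 25000 nM, with a range from 8000 nM to 80000 nM.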

Compound 3, half-maximal inhibitory concentration: 9430 nM
Compound 3: middle estimate off by 2.7-fold (0.42 log units), on the high side; the measured number falls inside the stated range.
By their numbers in this assay, from the lowest: compounds 2, 3 and 1 (each within the scatter of the next).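

In this assay, the step of a 1.8-fold lower number from compound 1 to compound 3 (0.25 log units; within the scatter) shows that this position tolerates a large cut. The phenyl ring can give way to methyl on a saturated chain carbon bound to an amide-type nitrogen, turning benzyl into ethyl, and the read-out stays within the scatter, so for this pair the six-membered aromatic ring is not needed to keep the antiproliferative reading at this level. No measurement at hand speaks to why the two compounds read alike.

The compounds shown leave open how a longer chain such as hexyl, or a chain ending in an amine or a carboxylic acid, would read at this place. They also leave open whether any group here can move the number beyond the scatter.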